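Swapping the chlorophenyl arm for a diisopropylamino chain

The source may report more compounds than this note shows. Statements on the series, on what has been measured and on what is new or still open speak of the compounds shown alone.

Compound 1 `Clc1ccc(Cn2ccc3nc(-c4ccccc4)nc-3c2)cc1`: > 100000 nM
Compound 2 `CC(C)(C)c1ccc(Cn2ccc3nc(-c4ccccc4)nc-3c2)cc1`: 22000 nM
Compound 3 `O=C(O)c1ccc(Cn2ccc3nc(-c4ccccc4)nc-3c2)cc1`: > 100000 nM

In an ADME assay on MDBK cells (Bos taurus) for cytotoxicity (a lower number here means that less compound is tolerated, a higher number that more compound is tolerated), compound 1 gives only a limit, > 100000 nM. Compound 3 likewise gives only a limit, > 100000 nM, so these two compounds sit together at the limit of > 100000 nM in this assay, at which 2 of the 3 values shown sit. Compound 2 gives a real number, 22000 nM, and the step of an at least 4.5-fold lower number from compound 1 to compound 2 (0.65 log units; beyond the scatter) shows that a tert-butyl in place of chloro lowers the tolerated amount. Compound 4 `CC(C)N(CCn1ccc2nc(-c3ccccc3)nc-2c1)C(C)C` differs from compound 1 by (diisopropylamino)methyl in place of 4-chlorophenyl on a saturated chain carbon bound to an aromatic nitrogen. Among the measured compounds shown here, none of the measured steps alters this part of the molecule, so they bear on the change only loosely. Compound 4 is expected to give about 60000 nM, in the range 15000 nM to 150000 nM. The estimated step is therefore an at least 1.6-fold lower number from compound 1 to compound 4 (0.22 log units; that floor lies within the scatter), with a fair chance that only a limit is returned.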

Compound 4, half-maximal cytotoxic concentration: > 100000 nM
Compound 4: a limit, no number (the forecaster's own chance of this, stated with the estimate: 45%); middle value at least 1.6-fold (0.22 log units) away from the limit.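

In this assay compound 4 gives only a limit, > 100000 nM. Compound 1 also gives only a limit, so the step between these two compounds cannot be read. The compounds shown leave open whether (diisopropylamino)methyl in place of 4-chlorophenyl changes the tolerated amount at all.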